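Working notes: piperazine nitrogen exchange in the series

A few compounds are considered here, and "the series" means these few. Any claim that something is new, unique, unknown or untested is made for them only; others in the source may bear on it.

In a functional assay on HeLa cells (Homo sapiens) for antiproliferative activity, read by MTT assay, with a stated time of 48 h (a lower number here means a stronger inhibitor, a higher number a weaker inhibitor), compound 1 `CC1(C)CC(NC(=O)c2ccc(Nc3ncc([N+](=O)[O-])c(NC4CCCC4)n3)cc2)CC(C)(C)N1[O]` gives 55600 nM. Among the compounds with values here, compound 2 `CCN1CCN(c2nc(Nc3ccc(C(=O)NC4CC(C)(C)N([O])C(C)(C)C4)cc3)ncc2[N+](=O)[O-])CC1` gives 17500 nM in this assay, the lowest of the two numbers measured so far, and the only measured step, a 3.2-fold lower number from compound 1 to compound 2 (0.50 log units; beyond the scatter), separates it from compound 1. Compound 3 `CC1(C)CC(NC(=O)c2ccc(Nc3ncc([N+](=O)[O-])c(N4CCN(c5ccc(F)cc5)CC4)n3)cc2)CC(C)(C)N1[O]` awaits measurement in this assay. It differs from compound 2 by 4-fluorophenyl in place of ethyl on an amine nitrogen in a ring. Within the data shown here, the step of a 3.2-fold lower number from compound 1 to compound 2 (0.50 log units; beyond the scatter) concerns a different place on the shared core, the aromatic carbon that carries cyclopentylamino or 4-ethylpiperazin-1-yl, so no measured step bears on an exchange at the amine nitrogen in the ring. With nothing measured to lean on, a step of the expected size a 1.2-fold lower number from compound 2 to compound 3 (0.07 log units; within the scatter) is put near the scatter, with no direction claimed beyond it. For compound 3 the expected value in this assay is 15000 nM, within a range from 5000 nM to 45000 nM.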

Compound 3, half-maximal inhibitory concentration: 25300 nM
The estimate for compound 3 lay 1.7-fold (0.23 log units) below the measured number; low and high end bracket the measured number.
By their numbers in this assay, from the lowest: compounds 2 and 3 (each within the scatter of the next); then compound 1.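

Within the data shown here, at the amine nitrogen in the ring, the first exchange to be read in this assay is a 1.4-fold higher number from compound 2 to compound 3 (0.16 log units; within the scatter), so ethyl and 4-fluorophenyl cannot be told apart at this position. The entering group brings 7 heavy atoms and a six-membered aromatic ring in place of 2 heavy atoms and no ring, yet the step stays within the scatter, something the earlier step at the aromatic carbon could not show. Nothing measured here accounts for this result.

On these data alone, whether any group at this nitrogen moves the number beyond the scatter remains open, for example a longer alkyl chain, a benzyl group or a carboxylic acid. Two groups also cannot show whether the 4-fluorophenyl result reflects aryl groups at this nitrogen in general.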